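Amide nitrogen substituent: aromatic ring to open chain

The source may hold more compounds than are shown below. What is called first, only, known or untested is meant among the compounds shown, and "the series" means these compounds.

The three measured compounds share one core and differ only in the group on the amide nitrogen. In a physicochemical assay for lipophilicity, using the shake flask method, in phosphate buffer, measured as octanol-water partition, at pH 7.4 (a lower number here means a more polar compound, a higher number a more lipophilic compound), compound 1 `COc1cc(-c2cc(C(=O)O)c3ccccc3n2)ccc1OCC(=O)Nc1ccccc1F` gives 0.9. In this assay compound 2 `COc1cc(-c2cc(C(=O)O)c3ccccc3n2)ccc1OCC(=O)NCc1ccco1` gives -0.3, and compound 3 `COc1cc(-c2cc(C(=O)O)c3ccccc3n2)ccc1OCC(=O)NCc1cccs1` gives 0. The steps read a number 1.20 log units lower from compound 1 to compound 2 (beyond the scatter) and a number 0.90 log units lower from compound 1 to compound 3 (beyond the scatter), both beyond the scatter, while a number 0.30 log units higher from compound 2 to compound 3 (within the scatter) stays within it. Compound 3 therefore holds the second highest of the three numbers, though its gap to compound 2 is within the scatter and only its gap to compound 1 is clear.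

Compound 4 `CCCCCCNC(=O)COc1ccc(-c2cc(C(=O)O)c3ccccc3n2)cc1OC` differs from compound 3 by pentyl in place of thiophen-2-yl on a saturated chain carbon bound to an amide-type nitrogen. For the measured compounds named here, one measured step sits at this position, a number 0.30 log units higher from compound 2 to compound 3 (within the scatter), and it exchanges one five-membered aromatic ring for another of like size; no measured step replaces the ring with an open chain, so the measured data give no direct guide to the size of this change. A step of a number 0.70 log units higher from compound 3 to compound 4 (beyond the scatter) in this assay is expected, upward and beyond the scatter. Compound 4 is estimated at 0.7, with a range from 0.1 to 1.3.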

Compound 4, distribution coefficient: 1
Compound 4: the middle estimate sits 0.30 log units below what was measured; the measured number falls inside the stated range.
By their numbers in this assay, from the lowest: compounds 2 and 3 (each within the scatter of the next); then compounds 1 and 4 (each within the scatter of the next).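

Replacing a five-membered aromatic ring with an open chain at this position, on a saturated chain carbon bound to an amide-type nitrogen, has a clear effect in this assay (a number 1.00 log units higher from compound 3 to compound 4 (beyond the scatter)) and (a number 1.30 log units higher from compound 2 to compound 4 (beyond the scatter)), whereas the ring-for-ring exchange had stayed within the scatter. Hexyl in place of 2-fluorophenyl on an amide-type nitrogen gives a step within the scatter (a number 0.10 log units higher from compound 1 to compound 4 (within the scatter)), so compound 1 and compound 4 stand level, although neither ring-bearing methyl group had stayed within the scatter of compound 1. No supporting evidence accounts for these differences.

Still open, on these data alone, is whether a longer chain such as octyl would move the number further along this series. A hexyl chain carrying an amine or a hydroxyl group also remains to be placed against compound 4.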